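Amidine to Carbamoyl on a Chemokine Receptor Antagonist

The source may report more compounds than this note shows. Statements on the series, on what has been measured and on what is new or still open speak of the compounds shown alone.

Measured compounds:
compound 1 `CC(=O)c1cnc(N2CCN(C3CCN(Cc4ccc(Cl)cc4)CC3)[C@@H](C)C2)c(Cl)c1` – 520 nM
compound 2 `C[C@H]1CN(c2ncc(C(=N)N)cc2Cl)CCN1C1CCN(Cc2ccc(Cl)cc2)CC1` – 80 nM

Of the compounds shown here, two have been measured in a functional assay for antagonist activity at C-X-C chemokine receptor type 3 (Homo sapiens); on this read-out lower numbers stand for stronger inhibition and higher numbers for weaker inhibition. Compound 1 `CC(=O)c1cnc(N2CCN(C3CCN(Cc4ccc(Cl)cc4)CC3)[C@@H](C)C2)c(Cl)c1` gives 520 nM in this assay, and compound 2 `C[C@H]1CN(c2ncc(C(=N)N)cc2Cl)CCN1C1CCN(Cc2ccc(Cl)cc2)CC1` gives 80 nM. Compound 2 therefore holds the lowest of the two numbers; its nearest neighbour is compound 1, and the step of a 6.5-fold lower number from compound 1 to compound 2 (0.81 log units; beyond the scatter) separates them.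

Compound 3 `C[C@H]1CN(c2ncc(C(N)=O)cc2Cl)CCN1C1CCN(Cc2ccc(Cl)cc2)CC1` is the next member of the set. It differs from compound 2 by a group of 3 heavy atoms (1 carbon, 1 nitrogen, 1 oxygen; no ring) in place of a group of 3 heavy atoms (1 carbon, 2 nitrogen; no ring), on an aromatic carbon. Among the measured compounds shown here, the only measured step that bears on this position is a 6.5-fold lower number from compound 1 to compound 2 (0.81 log units; beyond the scatter), where a group of two carbons and one oxygen gave way to a group of one carbon and two nitrogens. Compound 3 moves part of the way back: the carbamoyl that enters carries one oxygen and one nitrogen and one hydrogen-bond donor, between the two measured groups in its makeup. The expected step of a 4.4-fold higher number from compound 2 to compound 3 (0.64 log units; beyond the scatter) is therefore a modest rise in the number, though smaller than the full return to compound 1. Compound 3 is estimated at 350 nM in this assay, with a range from 100 nM to 1400 nM.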

Compound 3, half-maximal inhibitory concentration: 39 nM
For compound 3 the middle estimate is 9.0-fold (0.95 log units) above the measured one, and the stated range ends above it.
By their numbers in this assay, from the lowest: compound 3; then compound 2; then compound 1.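

Carbamoyl takes the place of the group in compound 2 on this aromatic carbon, para to a large group, and a 2.1-fold lower number from compound 2 to compound 3 (0.31 log units; beyond the scatter) in this assay shows that the position tolerates the loss of the second nitrogen and of a hydrogen-bond donor, as counted for the two groups, with no loss of inhibition. The earlier pair could not separate the effect of the carbonyl from that of the methyl, but a 13-fold lower number from compound 1 to compound 3 (1.12 log units; beyond the scatter) keeps the carbonyl and exchanges only methyl for amino, so among these three compounds the amino-bearing groups of compound 2 and compound 3 both give lower numbers than the acetyl group of compound 1. The data shown give no explanation for these shifts.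

The compounds shown leave open how a carboxylic acid, a methyl ester, a nitrile or an N-methylcarbamoyl group would read at this position. They also leave open whether the order seen here would hold if the chloro group were replaced by a fluoro or methyl group.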